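Sigma-1 Binding: Methoxy to Nitro on Two Related Cores

The source may hold more compounds than are shown below. What is called first, only, known or untested is meant among the compounds shown, and "the series" means these compounds.

Measured compounds in an assay on membranes from brain for displacement of a labelled ligand from Sigma non-opioid intracellular receptor 1 (Cavia porcellus), read by scintillation counting, with a stated time of 120 min; on this read-out lower numbers stand for stronger inhibition and higher numbers for weaker inhibition:
- compound 1, `COc1ccc(-c2scc3c2CCOC32CCN(Cc3ccccc3)CC2)cc1`: 1.5 nM
- compound 2, `O=[N+]([O-])c1ccc(-c2scc3c2CCOC32CCN(Cc3ccccc3)CC2)cc1`: 1.7 nM
- compound 3, `COc1ccc(-c2cc3c(s2)C2(CCN(Cc4ccccc4)CC2)OC(OC)C3)cc1`: 56 nM

Compound 1 and compound 2 share one core and differ only in a single group: nitro in place of methoxy on an aromatic carbon. The step this change made, a 1.1-fold higher number from compound 1 to compound 2 (0.05 log units; within the scatter), is small, so the two values say the same thing and neither compound can be called the stronger binder.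

Compound 3 has a different core. The difference between the two cores is not broken down here; what the numbers show is that compound 3 gives the highest value of the three, with compound 2 and compound 1 both well below it.

Compound 4, `COC1Cc2cc(-c3ccc([N+](=O)[O-])cc3)sc2C2(CCN(Cc3ccccc3)CC2)O1`, has not yet been measured in this assay. It differs from compound 3 in exactly the same way that compound 2 differs from compound 1: nitro in place of methoxy on an aromatic carbon. The place is described in identical words for both pairs, so this is the same change, carried out on the second core.

Among the measured compounds shown here, the only guide to its effect is the single earlier instance, where the change left the value essentially unmoved. On that basis the step from compound 3 to compound 4 is expected to be small as well, a 1.1-fold higher number from compound 3 to compound 4 (0.03 log units; within the scatter), because a 1.1-fold higher number from compound 1 to compound 2 (0.05 log units; within the scatter) lay within the usual scatter. One example cannot rule out a different outcome on a different core, so the range is kept wide. Compound 4 is estimated at 60 nM in this assay, between 25 nM and 150 nM.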

Compound 4, inhibition constant: 16 nM
Compound 4: the middle estimate sits 3.8-fold (0.57 log units) above what was measured; the whole stated range lies above it.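

On the second core, replacing 4-methoxyphenyl with 4-nitrophenyl in this assay gave a 3.5-fold lower number from compound 3 to compound 4 (0.54 log units; beyond the scatter), a modest gain in binding strength. Among the compounds shown here, the same replacement therefore did not have the same effect on the two cores: the same change on two cores in this assay, a 1.1-fold higher number (0.05 log units; within the scatter) from compound 1 to compound 2 and a 3.5-fold lower number (0.54 log units; beyond the scatter) from compound 3 to compound 4, 4.0-fold (0.60 log units) apart, beyond the scatter of two such steps With only two pairs, this shows that the result on one core was not a reliable guide to the result on the other, but it does not show which feature of the cores matters or how the change would behave on any further core.

From the compounds shown here alone, it remains open whether other groups in the same place on the aromatic ring, such as an amine or a nitrile, would also leave the number on the first core unmoved while lowering it on the second. The compounds shown also leave open which of the structural differences between the two cores accounts for the gap between the two steps.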